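Chain extension of a hexylsulfanyl side chain and host-cell tolerance

A few compounds are considered here, and "the series" means these few. Any claim that something is new, unique, unknown or untested is made for them only; others in the source may bear on it.

Compound 3 `CCCCCCSc1nc(N)nc2c1ncn2/C=C1/CC1(CO)CO` bears a hexylsulfanyl group on the shared core. In an ADME assay on HFF cells (Homo sapiens) for cytotoxicity, with a stated time of 8 days (a higher number here means that more compound is tolerated, a lower number that less compound is tolerated), compound 3 gives only a limit, > 300000 nM. Compound 1 `Nc1nc(NCc2ccccc2)c2ncn(/C=C3/CC3(CO)CO)c2n1`, with benzylamino in that position, likewise gives only a limit, > 300000 nM. Compound 2 `CCCCCOc1nc(N)nc2c1ncn2/C=C1/CC1(CO)CO`, with pentyloxy, gives 259000 nM in this assay. The measured steps of an at least 1.1-fold lower number from compound 1 to compound 2 (0.06 log units; that floor lies within the scatter) and an at least 1.1-fold higher number from compound 2 to compound 3 (0.06 log units; that floor lies within the scatter) are both small, while a step that the two limits leave unreadable from compound 1 to compound 3 cannot be read because of the limit of > 300000 nM in this assay, at which 2 of the 3 values shown sit. Compound 4 `CCCCCCCCSc1nc(N)nc2c1ncn2/C=C1/CC1(CO)CO` differs from compound 3 by ethyl in place of hydrogen on a saturated chain carbon, six bonds along the chain from a sulfur. Within the data shown here, no measured step touches chain length, so in this assay the expected step is an at least 1.0-fold lower number from compound 3 to compound 4 (0.02 log units; that floor lies within the scatter), within the scatter. Compound 4 is therefore estimated at 280000 nM, in the range 120000 nM to 300000 nM, quite possibly again only a limit.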

Compound 4, half-maximal cytotoxic concentration: > 300000 nM
Compound 4: a limit, no number; the forecaster's own chance of this, stated with the estimate: 60%; middle value at least 1.0-fold (0.02 log units) away from the limit.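

With ethyl in place of hydrogen on a saturated chain carbon, six bonds along the chain from a sulfur, compound 4 gives > 300000 nM in this assay, which is a limit and not a number. Set against pentyloxy, octylsulfanyl gives an at least 1.1-fold higher number from compound 2 to compound 4 (0.06 log units; that floor lies within the scatter). The steps to compound 4 from compound 3 and from compound 1 cannot be read, because both ends of each are limits: the limit of > 300000 nM in this assay, at which 3 of the 4 values shown sit.

As far as these compounds go, whether a longer chain, or a chain carrying an amine, would give a number in this assay stays open. So does any difference in tolerance between compound 3 and compound 4.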